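The source may hold more compounds than are shown below. What is called first, only, known or untested is meant among the compounds shown, and "the series" means these compounds.

- compound 1 `CC(C)CNC(=O)n1c(=O)oc2ccc(C3CCN(C)CC3)cc21` gives 60000 nM
- compound 2 `CN1CCN(c2ccc3c(c2)oc(=O)n3C(=O)NCCCCc2ccccc2)C(=O)C1` gives 20000 nM
- compound 3 `CC(C)CNC(=O)n1c(=O)oc2cc(C3CCCCN3C)ccc21` gives 190000 nM

In a physicochemical assay for solubility, read by HPLC, in phosphate buffer, measured as kinetic solubility, with a stated time of 1 h, at pH 7.4, tested at 250 uM (on this read-out lower numbers stand for lower solubility and higher numbers for higher solubility), compound 2 at 20000 nM stands lowest of the three, and the gaps up to compound 1 and compound 3 both lie beyond the usual scatter. Compound 4 `CCN1CCC(c2ccc3c(c2)oc(=O)n3C(=O)NCCCCc2ccccc2)CC1` carries 1-ethylpiperidin-4-yl in place of 4-methyl-2-oxopiperazin-1-yl on an aromatic carbon. For the measured compounds named here, no measured pair shows this change alone, so the expectation rests loosely on the higher numbers of compound 1 at 60000 nM and compound 3 at 190000 nM, which also differ elsewhere. A moderate upward step is expected in this assay, estimated as a 2.3-fold higher number from compound 2 to compound 4 (0.35 log units; beyond the scatter) and uncertain in size. Compound 4 is estimated at 45000 nM with an expected range of 15000 nM to 130000 nM in this read-out.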

Compound 4, solubility: 198000 nM
The estimate for compound 4 lay 4.4-fold (0.64 log units) below the measured number; the whole stated range lies below it.
By their numbers in this assay, from the lowest: compound 2; then compound 1; then compounds 3 and 4 (each within the scatter of the next).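

In this assay, for the compounds shown here, putting 1-ethylpiperidin-4-yl in place of 4-methyl-2-oxopiperazin-1-yl on this aromatic carbon gives a 9.9-fold higher number from compound 2 to compound 4 (1.00 log units; beyond the scatter), the first step at this position with the rest of the molecule unchanged. The swap keeps a six-membered non-aromatic ring and the same heavy-atom count, but removes the double bond outside aromatic rings and the oxygen. Nothing measured here accounts for the size of this step.

Going by these compounds, how 1-methylpiperidin-4-yl or morpholine would read at this position on the core of compound 2 remains open. So does whether the step would carry over to the different chain of compound 1.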